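A few compounds are considered here, and "the series" means these few. Any claim that something is new, unique, unknown or untested is made for them only; others in the source may bear on it.

Measured compounds and their values in an assay for inhibition of Dihydrofolate reductase (Bos taurus), using NADPH; a lower number here means a stronger inhibitor, a higher number a weaker inhibitor:
Compound 1, `Cc1ccc(N2C(N)=NC(N)=NC23CCCCC3)cc1`, gives > 100000 nM; this is a limit of the assay, not a number.
Compound 2, `COc1ccc(N2C(N)=NC(N)=NC23CCCCC3)cc1`, gives > 100000 nM; this too is a limit of the assay, not a number.
Compound 3, `Cc1ccc(CN2C(N)=NC(N)=NC2(C)C)cc1`, gives 24600 nM.

Compound 1 and compound 2 differ by one change, (methoxy in place of methyl on an aromatic carbon). The step between them, a step that the two limits leave unreadable from compound 1 to compound 2, cannot be read, because the limit of > 100000 nM in this assay, at which 2 of the 3 values shown sit, hides whatever difference in strength there may be. Compound 3 is built on a different core; how its core differs from that of compound 1 is not broken down here. For the measured compounds named here, its value is the only real number among the three.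

Compound 4, `COc1ccc(CN2C(N)=NC(N)=NC2(C)C)cc1`, has not yet been measured in this assay. It relates to compound 3 exactly as compound 2 relates to compound 1: methoxy in place of methyl on an aromatic carbon. The place description is the same word for word in both cases, so this is the same change made a second time. Going by the values given here, the one earlier instance of it left no readable step, so there is nothing measured to say whether this change helps or hurts. The expectation therefore rests on compound 3 alone and its value 24600 nM, with a step from compound 3 to compound 4 expected to be a 1.0-fold higher number from compound 3 to compound 4 (0.01 log units; within the scatter), that is, within the usual scatter. Compound 4 is thus expected to show about 25000 nM in this assay, with a plausible range from 8000 nM to 80000 nM.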

Compound 4, half-maximal inhibitory concentration: 58800 nM
The estimate for compound 4 lay 2.4-fold (0.37 log units) below the measured number; the range from low to high includes it.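

In this assay the swap of methyl for methoxy on an aromatic carbon, para to a large group, gives a 2.4-fold higher number from compound 3 to compound 4 (0.38 log units; beyond the scatter) and so makes a modestly weaker inhibitor on this core. On the core of compound 1 the same change cannot be read, because compound 1 and compound 2 both stand at a limit of the assay rather than at a number: the limit of > 100000 nM in this assay, at which 2 of the 4 values shown sit. This leaves a single readable instance of the change on a single core, so nothing here shows whether the step carries over to another core, either in direction or in size, and the unreadable pair neither supports nor contradicts it.

The compounds shown leave open how other groups at the same place on the core of compound 3, such as a chlorine atom, an amine or a carboxylic acid, would compare with methyl and methoxy. They also leave open whether a longer chain such as ethoxy would take the number further in the same direction, and whether the change would give a readable step on a core whose compounds stand clear of the limit.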